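Trimming the Benzyloxy Chain to Ethoxy on an Acylguanidine

A few compounds are considered here, and "the series" means these few. Any claim that something is new, unique, unknown or untested is made for them only; others in the source may bear on it.

Three acylguanidines share one core and differ at a single aromatic carbon. Compound 1 `Cc1cc(F)c(S(C)(=O)=O)cc1C(=O)N=C(N)N` carries fluoro there, and in a functional assay for inhibition of sodium/hydrogen exchanger (Oryctolagus cuniculus) (a higher number here means a weaker inhibitor, a lower number a stronger inhibitor), compound 1 gives 44 nM. Compound 2 `CCC(C)c1cc(C)c(C(=O)N=C(N)N)cc1S(C)(=O)=O` carries sec-butyl and gives 8 nM. Compound 3 `Cc1cc(OCc2ccccc2)c(S(C)(=O)=O)cc1C(=O)N=C(N)N` carries benzyloxy and gives 28 nM, the second highest of the three numbers: the step of a 1.6-fold lower number from compound 1 to compound 3 (0.20 log units; within the scatter) stays within the scatter, whereas a 3.5-fold higher number from compound 2 to compound 3 (0.54 log units; beyond the scatter) lies beyond it. Compound 4 `CCOc1cc(C)c(C(=O)N=C(N)N)cc1S(C)(=O)=O` is derived from compound 3 by methyl in place of phenyl on a saturated chain carbon bound to an oxygen on an aromatic ring, so that benzyloxy becomes ethoxy. Within the data shown here, no measured pair shows this exact change. Among the measured compounds shown here, the steps that bear on it are a 1.6-fold lower number from compound 1 to compound 3 (0.20 log units; within the scatter) and a 3.5-fold higher number from compound 2 to compound 3 (0.54 log units; beyond the scatter), which together show that what sits at this position has shifted the number only by small or modest amounts across fluoro, sec-butyl and benzyloxy. Shortening the chain while keeping an oxygen on the ring is expected to leave the number close to that of compound 3. Any step a 1.4-fold lower number from compound 3 to compound 4 (0.15 log units; within the scatter) is expected to fall within the scatter. Compound 4 is therefore estimated at 20 nM, with a range from 7 nM to 60 nM.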

Compound 4, half-maximal inhibitory concentration: 19 nM
Beside the measured number, compound 4's estimate is 1.1-fold (0.02 log units) above it, and the stated range covers the measured number.
By their numbers in this assay, from the lowest: compound 2; then compounds 4, 3 and 1 (each within the scatter of the next, the first and the last beyond it).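

With the phenyl gone and a methyl in its place, the number does not move beyond the scatter, a 1.5-fold lower number from compound 3 to compound 4 (0.17 log units; within the scatter), so in this assay compound 3 and compound 4 cannot be told apart and the phenyl of the benzyloxy chain is not needed to hold this level. Ethoxy nevertheless separates from fluoro where benzyloxy did not, a 2.3-fold lower number from compound 1 to compound 4 (0.36 log units; beyond the scatter), although the small gap between compound 3 and compound 4 means this shows only that ethoxy clears the scatter, not that it is a better group than benzyloxy. Among these compounds, neither oxygen-linked group reaches sec-butyl, and ethoxy also stays short of it, a 2.4-fold higher number from compound 2 to compound 4 (0.38 log units; beyond the scatter), so compound 2 remains the only compound set apart from all the others.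

The compounds shown offer no independent measurement that could account for these numbers. They also leave open whether the gap to sec-butyl is tied to the oxygen on the ring or to the shape of the chain, which a propyl group could address, and how methoxy, a longer chain such as butoxy, or an amine would read at this aromatic carbon.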